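Nitro to fluoro in a small series

This account rests on a few compounds, and the source may have more. Where it says the series, first, only, none or still open, it means among the compounds named here.

In a functional assay on HL-60 cells (Homo sapiens) for cytotoxicity, read by MTT assay, with a stated time of 46 h (a higher number here means a weaker inhibitor, a lower number a stronger inhibitor), compound 1 `O=C1/C(=C/c2ccccc2)C(c2ccccc2)Oc2ccc(O)cc21` gives 5800 nM and compound 2 `O=C1/C(=C/c2ccc(Br)cc2)C(c2ccccc2)Oc2ccccc21` gives 5700 nM with the two values lying within the scatter of each other. Compound 3 `O=c1c(Cc2ccc([N+](=O)[O-])cc2)coc2ccccc12` has the lowest number of the three at 2400 nM and lies beyond the scatter from both of the others. Among the compounds with values here, compound 4 `O=c1c(Cc2ccc(F)cc2)coc2ccccc12` is not yet measured and carries fluoro in place of nitro on an aromatic carbon, para to a large group fluoro in place of nitro on an aromatic carbon as its only change from compound 3. Within the data shown here, no measured pair shows this change, so the step remains a judgement. An estimated step of a 1.5-fold higher number from compound 3 to compound 4 (0.16 log units; within the scatter) is expected in this assay toward a higher number, within the scatter. For compound 4 the expected value is 3500 nM with an estimated range from 1400 nM to 9000 nM as a working figure.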

Compound 4, half-maximal inhibitory concentration: 19100 nM
The estimate for compound 4 lay 5.5-fold (0.74 log units) below the measured number; measured number above the stated range.
By their numbers in this assay, from the lowest: compound 3; then compounds 2 and 1 (each within the scatter of the next); then compound 4.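

At the aromatic carbon para to a large group, fluoro in place of nitro gives a clear change in this assay, with an 8.0-fold higher number from compound 3 to compound 4 (0.90 log units; beyond the scatter). Within the data shown here, this is the first pair that differs in one place, and it shows that the group at this position can move the number beyond the scatter. Nothing measured here bears on what lies behind the step.

The compounds shown carry only nitro and fluoro at this position, so it remains open whether an amine or a carboxylic acid there would lie nearer compound 3 or compound 4. On these data alone, whether the same change would give a step of similar size on the core of compound 1 also remains open.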